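The source may hold more compounds than are shown below. What is called first, only, known or untested is meant among the compounds shown, and "the series" means these compounds.

Compound 1 `COc1ccc2[nH]c(C(=O)N3CC(=O)N(Cc4ccccc4)[C@@H](CCN4CCC5(CC4)CC5)C3)cc2c1` anchors this comparison. In a physicochemical assay for solubility, read by spectrophotometry, in phosphate buffer, with a stated time of 2 h, at pH 7.4 (on this read-out lower numbers stand for lower solubility and higher numbers for higher solubility), compound 1 gives > 25000 nM, which is a limit of the assay rather than a number, as the limit of > 25000 nM in this assay, at which 1 of the 2 values shown sits, shows. Compound 2 `COc1ccc2[nH]c(C(=O)N3CC(=O)N(Cc4ccccc4)[C@@H](N4CCC(Cc5ccccc5)CC4)C3)cc2c1`, measured in this assay, gives 9300 nM. Compound 3 `COc1ccc2[nH]c(C(=O)N3CC(=O)N(Cc4ccccc4)[C@@H](CN4CC5CCCC5C4)C3)cc2c1` has not yet been measured; it differs from compound 1 in one place: a group of 8 heavy atoms (7 carbon, 1 nitrogen; one five-membered non-aromatic ring of carbon only, one five-membered non-aromatic ring with 1 hetero atom) in place of a group of 9 heavy atoms (8 carbon, 1 nitrogen; one three-membered non-aromatic ring of carbon only, one six-membered non-aromatic ring with 1 hetero atom), on a saturated chain carbon bound to a saturated ring carbon. Among the compounds with values here, no measured step between compounds is available here, so the size of the change must be judged from the structures alone, and a step not beyond the usual scatter is expected. Compound 3 is estimated at 25000 nM, with a range from 12000 nM to 50000 nM. That estimate means an expected step of a number no higher from compound 1 to compound 3 (the limit leaves the size open).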

Compound 3, solubility: 20700 nM
Compound 3: middle estimate off by 1.2-fold (0.08 log units), on the high side; measured number inside the range.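

Placing the group with two five-membered rings where the group with a three-membered and a six-membered ring stood, on a saturated chain carbon bound to a saturated ring carbon, gives the first step that can be read at this place: an at least 1.2-fold lower number from compound 1 to compound 3 (0.08 log units; that floor lies within the scatter). Only a floor for that step is known, and its true size stays hidden: the limit of > 25000 nM in this assay, at which 1 of the 3 values shown sits.

The compounds shown leave open how a morpholine or a carboxylic acid in this place would read in this assay, and whether any such group would move the number beyond the usual scatter.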